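Chloro for Fluoro on the Anilide Ring: Clearance Outlook

A few compounds are considered here, and "the series" means these few. Any claim that something is new, unique, unknown or untested is made for them only; others in the source may bear on it.

Measured compounds:
Compound 1, `Cc1cc(NC(=O)[C@H]2CN(C)C[C@@H]2c2ccc(/C=C/C(=O)Nc3ccccc3N)cc2)ccc1F`, 15 mL/min/kg
Compound 2, `Cc1cc(NC(=O)[C@H]2CN(C)C[C@@H]2c2ccc(/C=C/C(=O)Nc3ccccc3N)cc2)ccc1Cl`, 15 mL/min/kg
Compound 3, `CN1C[C@H](C(=O)Nc2ccc(F)cc2F)[C@@H](c2ccc(/C=C/C(=O)Nc3ccccc3N)cc2)C1`, 12 mL/min/kg

Three compounds have been run in an in vitro ADME assay on microsomes from liver (Homo sapiens) for pharmacokinetics, read by LC-MS, with a stated time of 10 min, tested at 1 uM; on this read-out higher numbers stand for fast clearance and lower numbers for slow clearance. Compound 1 gives 15 mL/min/kg in this assay, compound 2 gives 15 mL/min/kg and compound 3 gives 12 mL/min/kg. The three numbers sit within the scatter of one another, so no order among them can be read.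

Compound 1 and compound 3 differ in the anilide ring: 2,4-difluorophenyl in place of 4-fluoro-3-methylphenyl on an amide-type nitrogen. That swap gave a 1.3-fold lower number from compound 1 to compound 3 (0.10 log units; within the scatter), and from compound 2 the same comparison reads a 1.3-fold lower number from compound 2 to compound 3 (0.10 log units; within the scatter).

The change from compound 1 to compound 2 is chloro in place of fluoro on an aromatic carbon, and it gave no change at the digits printed from compound 1 to compound 2 (within the scatter). Compound 4, `CN1C[C@H](C(=O)Nc2ccc(Cl)cc2F)[C@@H](c2ccc(/C=C/C(=O)Nc3ccccc3N)cc2)C1`, has not yet been measured; it stands to compound 3 as compound 2 stands to compound 1: chloro in place of fluoro on an aromatic carbon. It is the same kind of change, though not in the same surroundings: in compound 1 the carbon bearing the halogen is ortho to a methyl group, whereas in compound 3 it is meta to a fluoro group, in both cases para to a large group.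

Because no change at the digits printed from compound 1 to compound 2 (within the scatter), compound 4 is expected to show a step of about a 1.1-fold higher number from compound 3 to compound 4 (0.03 log units; within the scatter) in this assay, with the width of the usual scatter as the main uncertainty. The estimate for compound 4 in this assay is 13 mL/min/kg, within 7 mL/min/kg to 26 mL/min/kg.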

Compound 4, clearance: 11 mL/min/kg
The estimate for compound 4 lay 1.2-fold (0.07 log units) above the measured number; the measured number falls inside the stated range.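

In this assay, chloro in place of fluoro on the anilide ring of compound 3 gave a 1.1-fold lower number from compound 3 to compound 4 (0.04 log units; within the scatter), and the two wider comparisons on that ring, a 1.4-fold lower number from compound 2 to compound 4 (0.13 log units; within the scatter) and a 1.4-fold lower number from compound 1 to compound 4 (0.13 log units; within the scatter), also stay within the usual scatter. Set beside the earlier step, the same swap reads alike in the two anilide settings: the same change on two cores in this assay, no change at the digits printed (within the scatter) from compound 1 to compound 2 and a 1.1-fold lower number (0.04 log units; within the scatter) from compound 3 to compound 4, 1.1-fold (0.04 log units) apart, within the scatter of two such steps. This shows that, in these two pairs, the swap carried over without a step that could be told from the scatter, but it does not show that chloro and fluoro are interchangeable throughout the series, and two pairs whose steps are this small cannot establish a rule or rule out a small real difference.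

The compounds shown leave open whether the same holds when a methoxy group, a nitrile or an amine takes the place of the halogen on the anilide ring. They also leave open how the clearance number responds to changes elsewhere on the shared core, such as a carboxylic acid in place of the methyl group on its ring nitrogen.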